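A few compounds are considered here, and "the series" means these few. Any claim that something is new, unique, unknown or untested is made for them only; others in the source may bear on it.

Compound 1 `CO[C@@H]1[C@H]2OC(=O)C[C@H]2O[C@@H]1[C@@H](O)c1ccccc1` is a micromolar-range starting point: in a functional assay on HL-60 cells (Homo sapiens) for inhibition, read by MTT assay, with a stated time of 72 h (a lower number here means a stronger inhibitor, a higher number a weaker inhibitor), compound 1 gives 19000 nM. Among the measured compounds shown here, only one measured neighbour stands beside it, compound 2 `CO[C@@H]1[C@H]2OC(=O)C[C@H]2O[C@@H]1[C@H](O)c1ccccc1`, and compound 2 gives 25000 nM. The step between them is a 1.3-fold higher number from compound 1 to compound 2 (0.12 log units; within the scatter), so the two sit level. What separates them is the fact that compounds 1 and 2 differ only in the configuration as drawn.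

Compound 3 `CO[C@@H]1[C@H]2OC(=O)C[C@H]2O[C@@H]1[C@@H](OC)c1ccccc1` keeps the configuration of compound 1 and makes a single change, methyl in place of hydrogen on an oxygen on a saturated carbon, or hydroxy to methoxy.

For the measured compounds named here, no measured step makes this exchange, so the evidence is thin. Going by the values given here, the one step available alters configuration rather than a group, and it stays within the scatter. It gives a loose guide only: this part of the molecule has so far shown no measurable change in this assay. Starting from compound 1 at 19000 nM, no step beyond the scatter and no clear direction is expected, with an estimated 1.1-fold higher number from compound 1 to compound 3 (0.02 log units; within the scatter). For compound 3 the estimate is 20000 nM, with an expected range from 8000 nM to 50000 nM.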

Compound 3, half-maximal inhibitory concentration: 4360 nM
Compound 3: the middle estimate sits 4.6-fold (0.66 log units) above what was measured; the measured number lies below the stated range.
By their numbers in this assay, from the lowest: compound 3; then compounds 1 and 2 (each within the scatter of the next).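

Putting a methyl on this oxygen, hydroxy to methoxy, gives a 4.4-fold lower number from compound 1 to compound 3 (0.64 log units; beyond the scatter) in this assay, so a single added carbon is enough to move the number at this position. Among the compounds shown here, the only earlier step, a 1.3-fold higher number from compound 1 to compound 2 (0.12 log units; within the scatter), changed the drawn configuration at the saturated chain carbon and left the two compounds level, so the earlier impression of an unresponsive position held only for that change and does not extend to what sits on the oxygen. Nothing known about these compounds speaks to why the methyl has this effect.

The compounds shown leave open whether a longer chain on this oxygen, such as ethyl, or an acetyl group would take the number lower still or bring it back up, and whether an amine in place of the hydroxy would behave at all like the methoxy. They also leave open whether the same methyl on the oxygen of compound 2 would give a comparable step, which would show whether the effect depends on the configuration at this carbon.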